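From 4-methoxyphenyl to 2-methoxyphenyl: a small swap

The source may hold more compounds than are shown below. What is called first, only, known or untested is meant among the compounds shown, and "the series" means these compounds.

Measured in a functional assay on HL-60 cells (Homo sapiens) for cytotoxicity, read by WST assay, with a stated time of 48 h; a higher number here means a weaker inhibitor, a lower number a stronger inhibitor:
Compound 1 `Oc1ccc(/C=C/C[C@H]2C[C@@H]([C@@H](O)c3ccccc3)CO[C@@H]2c2ccccc2)cc1`: 7380 nM
Compound 2 `COc1cccc(/C=C/C[C@H]2C[C@@H]([C@@H](O)c3ccccc3)CO[C@@H]2c2ccccc2)c1`: 9620 nM
Compound 3 `COc1ccc(/C=C/C[C@H]2C[C@@H]([C@@H](O)c3ccccc3)CO[C@@H]2c2ccccc2)cc1`: 9010 nM

Compound 3 stands within the scatter of both other compounds, so the three cannot be ranked. Compound 4 `COc1ccccc1/C=C/C[C@H]1C[C@@H]([C@@H](O)c2ccccc2)CO[C@@H]1c1ccccc1` has the same atoms as compound 3, joined differently: 2-methoxyphenyl in place of 4-methoxyphenyl on a double-bonded chain carbon bound to a double-bonded chain carbon. The closest measured precedent also exchanges one methoxyphenyl group for another: a 1.1-fold lower number from compound 2 to compound 3 (0.03 log units; within the scatter). The other changes at this place were equally small: a 1.3-fold higher number from compound 1 to compound 2 (0.12 log units; within the scatter) and a 1.2-fold higher number from compound 1 to compound 3 (0.09 log units; within the scatter). Among the compounds with values here, no measured compound carries 2-methoxyphenyl, so this remains an extrapolation. No step beyond the scatter is expected in this assay. The expected step is a 1.0-fold lower number from compound 3 to compound 4 (0.00 log units; within the scatter). The estimated value for compound 4 is 9000 nM. The expected range for compound 4 runs from 5000 nM to 16000 nM.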

Compound 4, half-maximal inhibitory concentration: 10100 nM
Compound 4: the middle estimate sits 1.1-fold (0.05 log units) below what was measured; low and high end bracket the measured number.
By their numbers in this assay, from the lowest: compounds 1, 3, 2 and 4 (each within the scatter of the next).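

With 2-methoxyphenyl in place, the methoxy group has now been tried at all three ring positions in this assay, and the position makes no clear difference: the change gives a 1.1-fold higher number from compound 3 to compound 4 (0.05 log units; within the scatter) and also a 1.0-fold higher number from compound 2 to compound 4 (0.02 log units; within the scatter). The 4-hydroxyphenyl comparison shows the same picture, with a 1.4-fold higher number from compound 1 to compound 4 (0.14 log units; within the scatter). Nothing available explains why these numbers stay so close. Still open, from the compounds shown here alone, is whether a very different group on this ring, such as an amine or a carboxylic acid, would shift the number beyond the scatter.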